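The compounds below may be only part of what the source reports. "The series", "measured", "known", "first", "only" and "open" are said of these compounds alone.

In a functional assay on HT-29 cells (Homo sapiens) for cytotoxicity, read by MTT assay, with a stated time of 72 h (a lower number here means a stronger inhibitor, a higher number a weaker inhibitor), compound 1 (`O=C(CN1CCN(c2nnc(Cc3ccncc3)c3ccccc23)CC1)Nc1cccc(F)c1`) gives 6130 nM and stands lowest of the three measured numbers, with compound 2 (`Cc1cccc(Cl)c1NC(=O)CN1CCN(c2nnc(Cc3ccccc3)c3ccccc23)CC1`) at 53600 nM and compound 3 (`O=C(CN1CCN(c2nnc(Cc3ccccc3)c3ccccc23)CC1)Nc1cccc(F)c1`) at 95000 nM higher up. Compound 4 (`Cc1ccccc1NC(=O)CN1CCN(c2nnc(Cc3ccncc3)c3ccccc23)CC1`) differs from compound 1 by one change on an amide-type nitrogen, 2-methylphenyl in place of 3-fluorophenyl (2-methylphenyl in place of 3-fluorophenyl on an amide-type nitrogen). The large step of a 15-fold higher number from compound 1 to compound 3 (1.19 log units; beyond the scatter) belongs to another place, phenyl in place of pyridin-4-yl, and does not speak to this swap. Because of a 1.8-fold higher number from compound 2 to compound 3 (0.25 log units; within the scatter) on the same nitrogen, where 3-fluorophenyl replaces 2-chloro-6-methylphenyl and the difference stays within the scatter, no step beyond the scatter is expected in this assay for this swap. Within the data shown here, that evidence comes with phenyl rather than pyridin-4-yl on the saturated chain carbon, and no measured compound carries 2-methylphenyl, so the range stays wide. The expected change is a 1.2-fold lower number from compound 1 to compound 4 (0.09 log units; within the scatter) and is estimated to stay within the scatter. Compound 4 is estimated at 5000 nM with a range of 1800 nM to 16000 nM as the expected span.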

Compound 4, half-maximal inhibitory concentration: 15000 nM
For compound 4 the middle estimate is 3.0-fold (0.48 log units) below the measured one; the range from low to high includes it.
By their numbers in this assay, from the lowest: compound 1; then compound 4; then compounds 2 and 3 (each within the scatter of the next).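

With pyridin-4-yl held in place, the swap on the amide-type nitrogen gives a 2.4-fold higher number from compound 1 to compound 4 (0.39 log units; beyond the scatter) in this assay, so the choice of aryl group at this position can move the number beyond the scatter. Among these compounds, the only earlier step on this nitrogen, a 1.8-fold higher number from compound 2 to compound 3 (0.25 log units; within the scatter), stayed within the scatter, involved a different pair of aryl groups and carried phenyl rather than pyridin-4-yl on the saturated chain carbon. No measurement shown here accounts for the new step.

The compounds shown leave open whether 2-methylphenyl and 3-fluorophenyl would differ by a similar step with phenyl in place of pyridin-4-yl, as no pair tests this. They also leave open how an unsubstituted phenyl or a cyclohexyl on this nitrogen would read in this assay.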